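Methyl on the anilide ring of compound 2

The source may hold more compounds than are shown below. What is called first, only, known or untested is meant among the compounds shown, and "the series" means these compounds.

Of the compounds shown here, three on one shared core have been measured. Compound 1 `COc1cc2c(cc1OC)C(CC(=O)O)CC2` gives 27.5% in a functional assay on the whole organism (strain Wistar) for inhibition, with Rattus norvegicus as the target, read by paw edema, with a stated time of 3 h, at a dose of 100 mg/kg; a lower number here means less inhibition, a higher number more inhibition at the dose given (going by the name of the read-out). Compound 2 `COc1cc2c(cc1OC)C(CC(=O)Nc1ccccc1)CC2` gives 36.2% in this assay, and compound 3 `COc1cc2c(cc1OC)C(CC(=O)Nc1ccc(Br)cc1)CC2` gives 43.5%. Compound 2 stands second highest of the three numbers, with the step of a number 7.3 percentage points higher from compound 2 to compound 3 (within the scatter) on one side and the step of a number 8.7 percentage points higher from compound 1 to compound 2 (within the scatter) on the other, both within the scatter. Among the measured compounds shown here, only the step of a number 16 percentage points higher from compound 1 to compound 3 (beyond the scatter) exceeds the scatter.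

Compound 4 `COc1cc2c(cc1OC)C(CC(=O)Nc1ccc(C)cc1)CC2` differs from compound 2 in one place: methyl in place of hydrogen on an aromatic carbon. The measured step that bears most directly on this is the one at the same place on the aromatic ring, where bromo replaced hydrogen, a number 7.3 percentage points higher from compound 2 to compound 3 (within the scatter), which lay within the scatter. For the measured compounds named here, no measured step involves methyl, so nothing separates a small group at that place from a larger one. The expectation is therefore a step of the same order: a small rise in this assay, or none beyond the scatter. Compound 4 is estimated to give 40% in this assay, with a range from 28% to 52%. For compound 4 this amounts to an expected step of a number 3.8 percentage points higher from compound 2 to compound 4 (within the scatter).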

Compound 4, a percentage reported as inhibition, in the whole organism at one dose (the size of the read-out at that dose, not a potency): 34.8%
Beside the measured number, compound 4's estimate is 5.2 percentage points above it; the range from low to high includes it.
By their numbers in this assay, from the lowest: compounds 1, 4, 2 and 3 (each within the scatter of the next, the first and the last beyond it).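

Methyl is the first carbon group seen at this place on the anilide ring, para to a large group, and in this assay it gives a number 1.4 percentage points lower from compound 2 to compound 4 (within the scatter), so it does not separate from hydrogen there. It does not separate from bromo at the same place either, with a number 8.7 percentage points lower from compound 3 to compound 4 (within the scatter), which means that none of the three groups seen there, hydrogen, bromo and methyl, can be told from the next by its number. The change from the acid also reads differently with this anilide: (4-methylphenyl)amino in place of hydroxy gives a number 7.3 percentage points higher from compound 1 to compound 4 (within the scatter), whereas (4-bromophenyl)amino gave a number 16 percentage points higher from compound 1 to compound 3 (beyond the scatter), so among the substituted anilides only the bromo compound stands clear of compound 1 in this read-out.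

No measurement shown here speaks to the reason for any of these steps. From the compounds shown here alone, whether a group such as methoxy, an amine, a carboxylic acid or a longer chain like butyl at this place would move the number beyond the scatter from compound 2 stays open, as does how these compounds would compare at any other dose.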